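The source may hold more compounds than are shown below. What is called first, only, known or untested is meant among the compounds shown, and "the series" means these compounds.

Measured so far:
Compound 1 `CCCn1c(=O)c2nc(-c3cnn(Cc4ccccc4C(F)(F)F)c3)[nH]c2n(CCC)c1=O`: in an assay on CHO cells for displacement of a labelled ligand from adenosine receptor A1 (Homo sapiens) (on this read-out higher numbers stand for weaker inhibition and lower numbers for stronger inhibition), compound 1 gives 44 nM.
Compound 2 `CCCn1c(=O)c2nc(-c3cnn(Cc4ccccc4C)c3)[nH]c2n(CCC)c1=O`: in this assay compound 2 gives 22 nM.
Compound 3 `CCCn1c(=O)c2nc(-c3cnn(Cc4c(F)cc(F)cc4F)c3)[nH]c2n(CCC)c1=O`: in this assay compound 3 has the entry "not determined" (no result reported).

Compound 3 therefore stands nowhere on the numbers; its value in this assay was not determined. Among the compounds with values here, the only step between measured compounds, a 2.0-fold lower number from compound 1 to compound 2 (0.30 log units; within the scatter), swaps one group on the benzyl ring and lies within the scatter. Compound 4 `CCCn1c(=O)c2nc(-c3cnn(Cc4ccccc4OC)c3)[nH]c2n(CCC)c1=O` arises from compound 3 by 2-methoxyphenyl in place of 2,4,6-trifluorophenyl on a saturated chain carbon bound to an aromatic nitrogen. Within the data shown here, no measured step covers this change directly. Compound 1 gives 44 nM and compound 2 gives 22 nM with comparable groups on the benzyl ring, which anchors the expectation. For compound 4 the estimated value in this assay is 30 nM, with a range of 10 nM to 100 nM.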

Compound 4, inhibition constant: 59 nM
The estimate for compound 4 lay 2.0-fold (0.29 log units) below the measured number; the measured number falls inside the stated range.
By their numbers in this assay, from the lowest: compounds 2, 1 and 4 (each within the scatter of the next, the first and the last beyond it).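

In this assay methoxy on an aromatic carbon of the benzyl ring can now be set against both earlier groups: there is a 2.7-fold higher number from compound 2 to compound 4 (0.43 log units; beyond the scatter) and also a 1.3-fold higher number from compound 1 to compound 4 (0.13 log units; within the scatter). Methyl and methoxy are the only pair of the three separated beyond the scatter, while trifluoromethyl lies within the scatter of each. Nothing at hand gives a reason for that separation.

Still open, from the compounds shown here alone, is how an amine or a carboxylic acid in place of methoxy would read. Going by these compounds, the standing of 2,4,6-trifluorobenzyl against these groups also remains open.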